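The source may hold more compounds than are shown below. What is called first, only, known or untested is meant among the compounds shown, and "the series" means these compounds.

Compound 1 `FC(F)(F)c1ccccc1-c1ccc2[nH]c(C3=NOC4(CCCCC4)C3)nc2c1`: 75%
Compound 2 `FC(F)(F)Oc1ccccc1-c1ccc2[nH]c(C3=NOC4(CCCCC4)C3)nc2c1`: 74%

Both values come from an ADME assay on microsomes from liver (Rattus norvegicus) for metabolic stability, with a stated time of 10 min; on this read-out lower numbers stand for a less stable compound and higher numbers for a more stable compound. With only these two measured, compound 1 stands level with compound 2 within the scatter. Compound 3 `Fc1cc(-c2ccccc2C(F)(F)F)cc2nc(C3=NOC4(CCCCC4)C3)[nH]c12` alters compound 1 in one place: fluoro in place of hydrogen on an aromatic carbon. Among the compounds with values here, only one measured step bears on this: a number 1 percentage points lower from compound 1 to compound 2 (within the scatter). It swapped trifluoromethyl for trifluoromethoxy, a different change in a different place, so it is only a weak guide. It gives no reason to expect a shift in either direction. The expected step is a number 2 percentage points lower from compound 1 to compound 3 (within the scatter), which would stay within the scatter. For compound 3 the estimated value is 73%, with an expected range of 60% to 85%.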

Compound 3, percent of the compound remaining: 100%
For compound 3 the middle estimate is 27 percentage points below the measured one; the whole stated range lies below it.
By their numbers in this assay, from the lowest: compounds 2 and 1 (each within the scatter of the next); then compound 3.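

In this assay, within the data shown here, a small change to the core matters far more than the earlier compounds suggested: fluoro in place of hydrogen, on the aromatic carbon ortho to a fused ring, gives a number 25 percentage points higher from compound 1 to compound 3 (beyond the scatter). The trifluoromethoxy swap elsewhere in the molecule gave only a number 1 percentage points lower from compound 1 to compound 2 (within the scatter). No available evidence explains this rise.

From the compounds shown here alone, it remains open whether a chloro or methoxy group on this same carbon would behave like fluoro. Going by these compounds, whether fluoro would give a similar step on compound 2 also remains open.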